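This account rests on a few compounds, and the source may have more. Where it says the series, first, only, none or still open, it means among the compounds named here.

Of the compounds shown here, three built on a shared core have so far been measured in a functional assay, read by spectrophotometry, with a stated time of 5 min; on this read-out higher numbers stand for weaker inhibition and lower numbers for stronger inhibition. Compound 1 `O=c1cc(/C=N\c2ccccc2O)c2c(OCc3ccccc3)cc(OCc3ccccc3)cc2o1` gives 33100 nM. Compound 3 `O=c1cc(/C=N\c2ccc(O)cc2)c2c(OCc3ccccc3)cc(OCc3ccccc3)cc2o1` gives 249000 nM, the higher of the two numbers, the gap being a 7.5-fold higher number from compound 1 to compound 3 (0.88 log units; beyond the scatter). For compound 2 `O=c1cc(/C=N\O)c2c(OCc3ccccc3)cc(OCc3ccccc3)cc2o1` the result is not a number but (the limit of > 2000000 nM in this assay, at which 1 of the 3 values shown sits), recorded as > 2000000 nM. Between compound 1 and compound 2 the data show an at least 60-fold higher number from compound 1 to compound 2 (1.78 log units; beyond the scatter), and between compound 2 and compound 3 they show an at least 8.0-fold lower number from compound 2 to compound 3 (0.90 log units; beyond the scatter).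

Compound 4 `O=c1cc(/C=N\Nc2ccccc2)c2c(OCc3ccccc3)cc(OCc3ccccc3)cc2o1` has not yet been measured; it differs from compound 3 by anilino in place of 4-hydroxyphenyl on a double-bonded nitrogen. Within the data shown here, no measured step swaps a hydroxyphenyl for an anilino group. The nearest guidance is that the two compounds carrying an aromatic ring on the double-bonded nitrogen, compound 1 and compound 3, both give numbers rather than a limit, and differ from each other by a 7.5-fold higher number from compound 1 to compound 3 (0.88 log units; beyond the scatter). The expected step is therefore modest, a 2.5-fold lower number from compound 3 to compound 4 (0.40 log units; beyond the scatter). Compound 4 is expected to give 100000 nM, with a range from 20000 nM to 600000 nM.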

Compound 4, half-maximal inhibitory concentration: 303000 nM
For compound 4 the middle estimate is 3.0-fold (0.48 log units) below the measured one, within the range that was stated.
By their numbers in this assay, from the lowest: compound 1; then compounds 3 and 4 (each within the scatter of the next). At a limit, above all of these: compound 2.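

In this assay, anilino in place of 4-hydroxyphenyl on a double-bonded nitrogen gives a 1.2-fold higher number from compound 3 to compound 4 (0.09 log units; within the scatter), so a hydroxyphenyl group is not required for a reading at this level. The 2-hydroxyphenyl group of the earlier series stays apart from the new group, with anilino in its place giving a 9.2-fold higher number from compound 1 to compound 4 (0.96 log units; beyond the scatter). Anilino in place of hydroxy gives an at least 6.6-fold lower number from compound 2 to compound 4 (0.81 log units; beyond the scatter), a step whose starting point is a limit and not a number: the limit of > 2000000 nM in this assay, at which 1 of the 4 values shown sits.

The compounds shown leave open whether an unsubstituted phenyl on the double-bonded nitrogen, or a ring carrying a carboxylic acid, would read closer to compound 1 or to compounds 3 and 4. Also open, as far as these compounds go, is whether a 2-aminophenyl group would match the 2-hydroxyphenyl group of compound 1.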